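A few compounds are considered here, and "the series" means these few. Any claim that something is new, unique, unknown or untested is made for them only; others in the source may bear on it.

Measured so far in a functional assay on MCF7 cells (Homo sapiens) for antiproliferative activity, read by MTT assay, with a stated time of 24 h; a higher number here means a weaker inhibitor, a lower number a stronger inhibitor:
compound 1 `Clc1ccc(C2=NN(c3ccc(-c4ccccc4)nn3)C(c3ccc(Cl)cc3)C2)cc1` gives 8800 nM
compound 2 `Fc1ccc(C2CC(c3ccc(Cl)cc3)=NN2c2ccc(-c3ccccc3)nn2)cc1` gives 3750 nM

Among the compounds with values here, compound 2 stands lowest of the two numbers; its only neighbour is compound 1, and the step of a 2.3-fold lower number from compound 1 to compound 2 (0.37 log units; beyond the scatter) is modest. Compound 3 `COc1cc(C2CC(c3ccc(Cl)cc3)=NN2c2ccc(-c3ccccc3)nn2)cc(OC)c1OC` has not yet been measured in this assay. It differs from compound 2 in one place: 3,4,5-trimethoxyphenyl in place of 4-fluorophenyl on a saturated ring carbon. Within the data shown here, no measured step covers this exchange. Among the measured compounds shown here, the single known step, from a chloro to a fluoro on the same saturated ring carbon of the shared core, shows that a change at this position can move the number beyond the scatter, but it says nothing about the 3,4,5-trimethoxyphenyl itself. The direction is therefore open, and the expected step from compound 2 to compound 3 is a 1.9-fold lower number from compound 2 to compound 3 (0.27 log units; within the scatter), carrying wide uncertainty. Compound 3 is estimated at 2000 nM, within a range from 500 nM to 8000 nM.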

Compound 3, half-maximal inhibitory concentration: 100000 nM
For compound 3 the middle estimate is 50-fold (1.70 log units) below the measured one; measured number outside the range, above it.
By their numbers in this assay, from the lowest: compound 2; then compound 1; then compound 3.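

In this assay the group on this saturated ring carbon proves able to do far more than shift the number slightly: 3,4,5-trimethoxyphenyl in place of 4-fluorophenyl gives a 27-fold higher number from compound 2 to compound 3 (1.43 log units; beyond the scatter) and in place of 4-chlorophenyl gives an 11-fold higher number from compound 1 to compound 3 (1.06 log units; beyond the scatter). Both steps are large, well beyond the modest step between the two halogen-bearing rings, so the exchange of one halogen for another gave no hint of how much this position can cost. No outside measurement is at hand to explain the drop. On these data alone, whether a phenyl ring carrying only one methoxy, or a plain phenyl, would stay nearer compound 2 remains open. So does the effect of an amine or a carboxylic acid on this ring.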